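The compounds below may be only part of what the source reports. "The series", "measured", "known", "first", "only" and "open" are said of these compounds alone.

Compound 1 `O=C(Nc1ccc(Oc2ccnc3[nH]ccc23)cc1)c1nn(-c2ccc(Cl)cc2)ccc1=O` in a functional assay on MCF7 cells (Homo sapiens) for cytotoxicity, read by MTT assay, with a stated time of 72 h (a lower number here means a stronger inhibitor, a higher number a weaker inhibitor), gives 10600 nM, while compound 2 `COc1ccc(-n2ccc(=O)c(C(=O)Nc3ccc(Oc4ccnc5[nH]ccc45)cc3)n2)cc1` gives 21600 nM. The step of a 2.0-fold higher number from compound 1 to compound 2 (0.31 log units; beyond the scatter) follows the change (methoxy in place of chloro on an aromatic carbon). Compound 3 `Cn1ccc2c(Oc3ccc(NC(=O)c4nn(-c5ccc(Cl)cc5)ccc4=O)cc3F)ccnc21` is built on a different core, and the difference between the two cores is not broken down here. For compound 3 this assay reports only a limit, > 60000 nM. That value stands at the limit of > 60000 nM in this assay, at which 1 of the 3 values shown sits. Compound 4 `COc1ccc(-n2ccc(=O)c(C(=O)Nc3ccc(Oc4ccnc5c4ccn5C)c(F)c3)n2)cc1` carries the same kind of change on that core, (methoxy in place of chloro on an aromatic carbon), and its place is described in the same words as before. Because the earlier step of a 2.0-fold higher number from compound 1 to compound 2 (0.31 log units; beyond the scatter) raised the number, the step that the limit leaves unreadable from compound 3 to compound 4 is expected in this assay. Compound 4 is therefore estimated at 120000 nM, most probably reported once more only as a limit.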

Compound 4, half-maximal inhibitory concentration: > 60000 nM
Compound 4 ended at the assay's limit (the forecaster's own chance of this, stated with the estimate: 85%); the middle value does not contradict the limit.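

In this assay compound 4 gives > 60000 nM, a limit and not a number. For the compounds shown here, compound 3 also stands only at a limit, so no step from compound 3 to compound 4 can be read. From the compounds shown here alone, what 4-methoxyphenyl in place of 4-chlorophenyl does on the core of compound 3 stays open.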